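The source may report more compounds than this note shows. Statements on the series, on what has been measured and on what is new or still open speak of the compounds shown alone.

Compound 3, with the structure `COc1cc(OC)c(/C=C/S(=O)(=O)Nc2ccc(OC)c(F)c2)c(OC)c1`, gives 200 nM in a functional assay on DU-145 cells (Homo sapiens) for cytotoxicity, read by trypan blue exclusion, with a stated time of 96 h; on this read-out higher numbers stand for weaker inhibition and lower numbers for stronger inhibition. That is the lowest of the three numbers recorded, but its neighbour compound 2, with the structure `COc1ccc(NS(=O)(=O)/C=C/c2c(OC)cccc2OC)cc1`, gives 375 nM, a gap that falls within the usual scatter, so the two cannot be ordered. Compound 1, with the structure `COc1ccc(NS(=O)(=O)/C=C/c2c(F)c(F)c(F)c(F)c2F)cc1N`, gives 75000 nM, which lies well beyond the scatter from compound 3.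

The account now turns to compound 4, with the structure `COc1cc(OC)c(/C=C/S(=O)(=O)Nc2ccc(OC)c(NC(C(=O)O)c3ccc(F)cc3)c2)c(OC)c1`, which has not yet been measured. It differs from compound 3 in one place: (carboxy(4-fluorophenyl)methyl)amino in place of fluoro on an aromatic carbon. For the measured compounds named here, no pair of measured compounds shows what such an exchange does here, so nothing measured can anchor the size of the step. The entering group is much larger than the fluoro it replaces and sits ortho to a methoxy group and meta to a large group. Given that compound 3 already gives 200 nM, a modest loss is expected, and the expected step from compound 3 to compound 4 is a 3.0-fold higher number from compound 3 to compound 4 (0.48 log units; beyond the scatter). Compound 4 is therefore estimated at 600 nM, within a range from 150 nM to 3000 nM.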

Compound 4, half-maximal inhibitory concentration: 75 nM
For compound 4 the middle estimate is 8.0-fold (0.90 log units) above the measured one, outside the stated range (below it).
By their numbers in this assay, from the lowest: compound 4; then compounds 3 and 2 (each within the scatter of the next); then compound 1.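

In this assay, putting (carboxy(4-fluorophenyl)methyl)amino in place of fluoro on this aromatic carbon gives a 2.7-fold lower number from compound 3 to compound 4 (0.43 log units; beyond the scatter). The earlier compounds shown here gave no view of this place, and this single exchange shows that an entering group of 12 heavy atoms, with its own six-membered aromatic ring, can stand ortho to the methoxy group without the number rising; here it falls. Nothing on hand offers a cause for this step. The compounds shown leave open which part of the entering group carries the step, since a plain amine, a benzylamino group without the carboxylic acid, or the methyl ester at this carbon would each separate those parts. As far as these compounds go, whether the 4-fluorophenyl ring matters, or could be an unsubstituted phenyl ring, also remains open.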